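Replacing the trifluoromethyl arm: compound 4 estimated

The compounds below may be only part of what the source reports. "The series", "measured", "known", "first", "only" and "open" are said of these compounds alone.

Measured compounds and values:
compound 1 `COc1ccc(/C=C/C(=O)Nc2cc(C(=O)c3cc(OC)c(OC)c(OC)c3)ccc2OC)cc1`: 10900 nM
compound 2 `COc1cccc(/C=C/C(=O)Nc2cc(C(=O)c3cc(OC)c(OC)c(OC)c3)ccc2OC)c1`: 5100 nM
compound 3 `COc1ccc(C(=O)c2cc(OC)c(OC)c(OC)c2)cc1NC(=O)/C=C/c1ccc(C(F)(F)F)cc1`: 2600 nM

All three compounds were tested in a functional assay on COLO 205 cells (Homo sapiens) for cytotoxicity, read by MTT assay, with a stated time of 72 h; on this read-out higher numbers stand for weaker inhibition and lower numbers for stronger inhibition. They share a common core and differ only in the aromatic ring on the double-bonded chain carbon. Compound 3 gives the lowest number of the three, with compound 2 nearest and compound 1 furthest; the step of a 2.0-fold lower number from compound 2 to compound 3 (0.29 log units; within the scatter) lies within the scatter, while a 4.2-fold lower number from compound 1 to compound 3 (0.62 log units; beyond the scatter) and a 2.1-fold lower number from compound 1 to compound 2 (0.33 log units; beyond the scatter) lie beyond it.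

Compound 4 `COc1cc(/C=C/C(=O)Nc2cc(C(=O)c3cc(OC)c(OC)c(OC)c3)ccc2OC)ccc1F` has not yet been measured. It differs from compound 3 in one place: 4-fluoro-3-methoxyphenyl in place of 4-(trifluoromethyl)phenyl on a double-bonded chain carbon bound to a double-bonded chain carbon. The entering ring carries a methoxy as in compound 2, plus a fluorine in place of a hydrogen. The closest guidance comes from compound 2 and compound 3, whose gap was small, so the expectation for compound 4 is a modest rise, estimated as a 1.9-fold higher number from compound 3 to compound 4 (0.28 log units; within the scatter). Compound 4 is therefore expected at 5000 nM, within a range of 2000 nM to 12500 nM.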

Compound 4, half-maximal inhibitory concentration: 11800 nM
Compound 4: middle estimate off by 2.4-fold (0.37 log units), on the low side, and the stated range covers the measured number.
By their numbers in this assay, from the lowest: compounds 3 and 2 (each within the scatter of the next); then compounds 1 and 4 (each within the scatter of the next).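

In this assay, fluoro in place of hydrogen on the ring of compound 2 gives a 2.3-fold higher number from compound 2 to compound 4 (0.36 log units; beyond the scatter) and shows that this single added atom can shift the number in the weaker direction. The full ring change gives a 4.5-fold higher number from compound 3 to compound 4 (0.66 log units; beyond the scatter) while the comparison with the 4-methoxyphenyl ring gives a 1.1-fold higher number from compound 1 to compound 4 (0.03 log units; within the scatter) and leaves those two compounds indistinguishable. Fluorine on this ring therefore does not by itself go with a lower number, since compound 3 carries it as trifluoromethyl and compound 4 carries it as fluoro.

No evidence at hand accounts for these steps. Still open, from the compounds shown here alone, is how an amine, a carboxylic acid or a chloro on this ring would read, and whether fluoro in place of hydrogen would give a similar step on the ring of compound 1.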